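From compound 2 to compound 3: a smaller group

A few compounds are considered here, and "the series" means these few. Any claim that something is new, unique, unknown or untested is made for them only; others in the source may bear on it.

In a functional assay on MDA-MB-231 cells (Homo sapiens) for inhibition, read by MTT assay, with a stated time of 48 h (on this read-out higher numbers stand for weaker inhibition and lower numbers for stronger inhibition), compound 1 (`COc1ccc(N(C)c2nc(C)nc3ccccc23)cc1OCCCCCC[Se]C#N`) gives 3550 nM and compound 2 (`COc1ccc(N(C)c2nc(C)nc3ccccc23)cc1C(=O)OCCCC[Se]C#N`) gives 554 nM, so compound 2 holds the lower of the two numbers. Compound 3 (`COc1ccc(N(C)c2nc(C)nc3ccccc23)cc1OCCCC[Se]C#N`) has not been measured. Relative to compound 2 it carries a group of 8 heavy atoms (5 carbon, 1 nitrogen, 1 oxygen, 1 selenium; no ring) in place of a group of 10 heavy atoms (6 carbon, 1 nitrogen, 2 oxygen, 1 selenium; no ring), on an aromatic carbon, ortho to a methoxy group. Among the measured compounds shown here, only one measured step bears on this change: a 6.4-fold lower number from compound 1 to compound 2 (0.81 log units; beyond the scatter), also an exchange of a group on an aromatic carbon. That step is modest but beyond the scatter, and a single step offers thin support. From it, a move of modest size toward weaker inhibition is expected in this assay, with the number staying short of that of compound 1. The expected change is a 2.2-fold higher number from compound 2 to compound 3 (0.34 log units; beyond the scatter). Compound 3 is estimated at 1200 nM, with an expected range of 400 nM to 3500 nM.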

Compound 3, half-maximal inhibitory concentration: 1350 nM
The estimate for compound 3 lay 1.1-fold (0.05 log units) below the measured number; the range from low to high includes it.
By their numbers in this assay, from the lowest: compound 2; then compound 3; then compound 1.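

Among the compounds shown here, compound 3 splits the single earlier step into two separate changes. In this assay, a 2.6-fold lower number from compound 1 to compound 3 (0.42 log units; beyond the scatter) comes from shortening the chain alone, with the oxygen on the aromatic ring kept, while a 2.4-fold higher number from compound 2 to compound 3 (0.39 log units; beyond the scatter) comes from losing the carbonyl at the aromatic carbon ortho to the methoxy group, with the chain length kept. Both steps are modest but beyond the scatter, so chain length and the carbonyl each register on this read-out, and no evidence at hand accounts for either step.

The compounds shown leave open whether an ester carrying the longer chain of compound 1 would follow the same shift seen with the ether chains. They also leave open how an amide in place of the ester, or a chain shorter than that of compound 3, would read.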